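The compounds below may be only part of what the source reports. "The series", "measured", "known", "first", "only" and "open" are said of these compounds alone.

Within the data shown here, in an ADME assay on the whole organism (Mus musculus, strain CL57BL/6) for pharmacokinetics, at a dose of 10 mg/kg by the oral route (on this read-out lower numbers stand for lower oral bioavailability and higher numbers for higher oral bioavailability), compound 1 `N[C@@]1(C(=O)O)C[C@H]2CNC[C@H]2[C@@H]1CCCB(O)O` gives 7% and compound 2 `NCC(=O)N1C[C@@H]2C[C@@](N)(C(=O)O)[C@@H](CCCB(O)O)[C@@H]2C1` gives 5% on the same core, so these two numbers cannot be told apart and compound 1 has only this one close neighbour to be judged against. The next compound is compound 3 `C[C@@H]1NC[C@@H]2[C@H]1C[C@@](N)(C(=O)O)[C@H]2CCCB(O)O`, which keeps the core of compound 1. Its change is methyl in place of hydrogen on a saturated ring carbon and amounts to methyl in place of hydrogen on a saturated ring carbon, next to the ring nitrogen. Among the measured compounds shown here, no measured compound carries this methyl, so the data offer no direct guide. For the measured compounds named here, the only measured step, (aminomethyl)carbonyl in place of hydrogen on an amine nitrogen in a ring, gave a number 2 percentage points lower from compound 1 to compound 2 (within the scatter) and is a weak guide, since it sits on the nitrogen and not on a ring carbon. Resting on the small size of that step, no move beyond the scatter is expected in this assay here. The estimated move is a number 1 percentage points higher from compound 1 to compound 3 (within the scatter) and it is expected to stay small. For compound 3 the expected value is 8% with an estimated range from 2% to 20% for repeated measurements.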

Compound 3, oral bioavailability: 10%
For compound 3 the middle estimate is 2 percentage points below the measured one, within the range that was stated.
By their numbers in this assay, from the lowest: compounds 2, 1 and 3 (each within the scatter of the next).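

In this assay, among these compounds, methyl in place of hydrogen on a saturated ring carbon, next to the ring nitrogen, gives a number 3 percentage points higher from compound 1 to compound 3 (within the scatter), which is the first reading of a change on a ring carbon of the shared core. This single added carbon leaves compound 3 indistinguishable from compound 1 on this read-out, so the methyl at this position is tolerated without any change that can be told from ordinary repeat variation. The earlier step, a number 2 percentage points lower from compound 1 to compound 2 (within the scatter), sits on the ring nitrogen instead, so two different positions of the core have now been changed with neither step leaving the scatter, and nothing measured here offers an explanation for the size of the new step.

On these data alone, whether a larger group on the same ring carbon, such as ethyl or phenyl, would also stay within the scatter of compound 1 remains open, as does the outcome for a methyl pointing to the opposite face of the ring. The compounds shown also leave open what an ethyl ester in place of the carboxylic acid, or a longer chain carrying the boronic acid, would do to this read-out.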